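Opening the Pyrrolidine Ring in a Protected Ester Side Chain

The compounds below may be only part of what the source reports. "The series", "measured", "known", "first", "only" and "open" are said of these compounds alone.

Compound 1 `C#CCn1cc(C(=O)NCCCOC(=O)[C@H]2OC(C)(C)N(C(=O)OC(C)(C)C)[C@@H]2c2ccccc2)c(=O)c2ccc(Cl)nc21` — > 10000 nM, a limit
Compound 2 `C#CCn1cc(C(=O)NCCCOC(=O)[C@H]2CCCN2C(=O)OC(C)(C)C)c(=O)c2ccc(Cl)nc21` — > 10000 nM, a limit

Both compounds share a core and differ only in the ester-linked end of the side chain. In a functional assay on A549 cells (Homo sapiens) for cytotoxicity, read by MTT assay, with a stated time of 72 h (on this read-out lower numbers stand for stronger inhibition and higher numbers for weaker inhibition), compound 2 gives > 10000 nM, which is a limit of the assay and not a number. Compound 1 likewise reaches only a limit in this assay. Both measured values stand at the limit of > 10000 nM in this assay, at which 2 of the 2 values shown sit, so no ranking between the two can be drawn.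

Compound 3 `C#CCn1cc(C(=O)NCCCOC(=O)[C@H](C)NC(=O)OC(C)(C)C)c(=O)c2ccc(Cl)nc21` is the next candidate. It carries 1-((tert-butoxycarbonyl)amino)ethyl in place of 1-(tert-butoxycarbonyl)pyrrolidin-2-yl on a carbonyl carbon. Among the compounds with values here, because both neighbours sit at the limit of > 10000 nM in this assay, at which 2 of the 2 values shown sit, no measured step gives a size or direction for this change, and the expectation is simply that compound 3 also stays at the limit. The estimate for compound 3 is 20000 nM, within 5000 nM to 100000 nM, which means an expected step that the limit leaves unreadable from compound 2 to compound 3 that is no more than the usual scatter.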

Compound 3, half-maximal inhibitory concentration: > 10000 nM
Compound 3: only a limit was reported; the forecaster's own chance of this, stated with the estimate: 85%; the middle value does not contradict the limit.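

In this assay compound 3 gives > 10000 nM, which is a limit and not a number. The change from compound 2 to compound 3 cannot be read, because both compounds sit at a limit: the limit of > 10000 nM in this assay, at which 3 of the 3 values shown sit.

The compounds shown leave open how these ester-linked side-chain ends rank against one another.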